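The source may report more compounds than this note shows. Statements on the series, on what has been measured and on what is new or still open speak of the compounds shown alone.

Measured compounds:
Compound 1, `O=C(O)Cn1c(SCCOc2ccc3ccccc3c2)nc2ccccc21`: 2500 nM
Compound 2, `O=C(O)Cn1c(SCCOc2cccc3ccccc23)nc2ccccc21`: 2000 nM
Compound 3, `O=C(O)Cn1c(SCCCOc2ccccc2)nc2ccccc21`: 786 nM

All three were tested in an assay on HEK293 cells for displacement of a labelled ligand from prostaglandin D2 receptor 2 (Homo sapiens); a higher number here means a weaker inhibitor, a lower number a stronger inhibitor. Compound 3 gives the lowest of the three numbers; the gaps to compound 2 and to compound 1 both lie beyond the usual scatter, so on these values compound 3 is the strongest inhibitor of the set. Compound 4, `O=C(O)Cn1c(SCCNc2ccccc2)nc2ccccc21`, has not yet been measured. It differs from compound 3 in one place: anilino in place of phenoxymethyl on a saturated chain carbon, two bonds along the chain from a sulfur. For the measured compounds named here, no pair of measured compounds shows this kind of change, so there is no step to lean on. Since the shared core and the acid are unchanged and the aromatic ring is kept, the author expects a modest move in this assay, most likely a small rise in the number, of a size that may not clearly exceed the scatter, a 1.5-fold higher number from compound 3 to compound 4 (0.18 log units; within the scatter). For compound 4 the estimate in this assay is 1200 nM, with a plausible range from 300 nM to 4500 nM.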

Compound 4, half-maximal inhibitory concentration: 7690 nM
For compound 4 the middle estimate is 6.4-fold (0.81 log units) below the measured one, and the stated range ends below it.
By their numbers in this assay, from the lowest: compound 3; then compounds 2 and 1 (each within the scatter of the next); then compound 4.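

In this assay, for the compounds shown here, this position proves sensitive to the change: anilino in place of phenoxymethyl on a saturated chain carbon, two bonds along the chain from a sulfur, gives a 9.8-fold higher number from compound 3 to compound 4 (0.99 log units; beyond the scatter), the first step in the set that differs in one place only. Both groups carry a six-membered aromatic ring of carbon only, so keeping that ring does not by itself preserve inhibition here; under the computed counts, phenoxymethyl has 0 hydrogen-bond donors and anilino has 1. Nothing at hand accounts for this loss.

The compounds shown leave open whether the hydrogen-bond donor or the exchange of oxygen for nitrogen is what matters at this position. A methylanilino or a benzyl group at the same place would bear on that question.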